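Dropping a Chloro Group from a Dichloro Core

The source may report more compounds than this note shows. Statements on the series, on what has been measured and on what is new or still open speak of the compounds shown alone.

Compound 1 `ClCc1cccc(Cn2cnc3c(Cl)nc(Cl)nc32)c1` has no result in a functional assay on SK-OV-3 cells (Homo sapiens) for cytotoxicity, read by sulforhodamine B assay, with a stated time of 48 h; a higher number here means a weaker inhibitor of growth, a lower number a stronger inhibitor of growth: for compound 1 the entry reads "not determined" (no result reported), so it offers no number to build on. For the measured compounds named here, compound 2 `ClCc1ccccc1Cn1cnc2nc(Cl)nc(Cl)c21` is therefore the only compound with a measurement: in this assay compound 2 gives 5880 nM, which makes it the sole reference point, with one further entry carrying no value at all. Compound 3 `ClCc1ccccc1Cn1cnc2ncnc(Cl)c21` is the compound awaiting measurement. It differs from compound 2 in one place: hydrogen in place of chloro on an aromatic carbon.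

Going by the values given here, no step between two measured compounds is available, so the effect of this change cannot be read from any measured pair, and the expectation rests on the single value of compound 2 alone. The step from compound 2 to compound 3 is expected to be a 1.4-fold higher number from compound 2 to compound 3 (0.16 log units; within the scatter) in this assay, a modest shift toward weaker growth inhibition that may well sit inside the usual scatter. Compound 3 is accordingly estimated to give 8500 nM in this assay, with a plausible range from 3000 nM to 25000 nM.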

Compound 3, concentration for 50% growth inhibition: 7580 nM
Compound 3: middle estimate off by 1.1-fold (0.05 log units), on the high side; measured number inside the range.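

Hydrogen in place of chloro on the aromatic carbon between two ring nitrogen atoms gives a 1.3-fold higher number from compound 2 to compound 3 (0.11 log units; within the scatter) in this assay. For the compounds shown here, this is the first measured step, and it shows that this single chlorine can be exchanged for hydrogen without the reading leaving the usual scatter, something the lone value of compound 2 could not show. Going by these compounds alone, compound 3 therefore still gives a measurable value with only one chloro group on the shared core, so growth inhibition at this level in this assay does not depend on the chloro group at this position; no measurement at hand bears on what lies behind this result.

The compounds shown leave open whether a different group on this same carbon, such as an amine or a methoxy group, would shift the number beyond the scatter, since hydrogen is the only replacement seen here. They also leave open what the remaining chloro group and the chloromethyl group contribute, as neither is varied in any measured pair.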